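The compounds below may be only part of what the source reports. "The series", "measured", "known", "first", "only" and "open" are said of these compounds alone.

Working notes on the series. In a functional assay on MV4-11 cells (Homo sapiens) for antiproliferative activity, read by MTT assay (on this read-out higher numbers stand for weaker inhibition of growth and lower numbers for stronger inhibition of growth), compound 1 (`COc1ccc(Nc2nc(NC3CCCC3)c3ccccc3n2)cc1`) gives 4910 nM while compound 2 (`COc1ccc(Nc2nc(NCCCO)c3ccccc3n2)cc1`) gives 8750 nM and compound 3 (`CNc1nc(Nc2ccc(OC)cc2)nc2ccccc12`) gives 3070 nM as its value. Compound 3 shares the low end of these numbers with compound 1 and stands apart only from compound 2, as the data show a 2.9-fold lower number from compound 2 to compound 3 (0.45 log units; beyond the scatter) as the one separated gap.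

Compound 4 (`COc1ccc(Nc2nc(NC3CC3)c3ccccc3n2)cc1`) carries cyclopropyl in place of methyl on a nitrogen on an aromatic ring and so reads as methylamino to cyclopropylamino. The nearest evidence is a 1.6-fold lower number from compound 1 to compound 3 (0.20 log units; within the scatter) which exchanges cyclopentyl for methyl on this same nitrogen. The exchange for 3-hydroxypropyl at that nitrogen gives a 1.8-fold higher number from compound 1 to compound 2 (0.25 log units; within the scatter) and is equally small. In this assay no step beyond the scatter is therefore expected. The estimated step is a 1.2-fold higher number from compound 3 to compound 4 (0.09 log units; within the scatter) and is expected to stay within the scatter. In this assay the estimated value for compound 4 is 3800 nM with an expected range of 1800 nM to 8000 nM around it.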

Compound 4, concentration for 50% growth inhibition: < 13400 nM
Compound 4 was reported as a limit; the forecaster's own chance of this, stated with the estimate: 3%; the middle value is on the limit's open side.
By their numbers in this assay, from the lowest: compounds 3, 1 and 2 (each within the scatter of the next, the first and the last beyond it).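

In this assay compound 4 is reported only as a limit, < 13400 nM, and its steps to compound 1, compound 2 and compound 3 cannot be read. The compounds shown leave open how cyclopropyl on this nitrogen compares with methyl, cyclopentyl or 3-hydroxypropyl.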